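Cytotoxicity when the hydroxyalkyl chain becomes cyanomethyl

The source may hold more compounds than are shown below. What is called first, only, known or untested is meant among the compounds shown, and "the series" means these compounds.

In an ADME assay on MT4 cells (Homo sapiens) for cytotoxicity, read by MTT assay, with a stated time of 5 days (on this read-out higher numbers stand for lower toxicity in this test and lower numbers for higher toxicity in this test), compound 3 `CC(O)CN(c1ccnc(Nc2ccc(C#N)cc2)n1)c1c(F)cc(-c2ccc(C#N)cc2)cc1F` gives 9800 nM, the lowest number among the three measured compounds. Compound 1 `CN(c1ccnc(Nc2ccc(C#N)cc2)n1)c1c(F)cc(-c2ccc(C#N)cc2)cc1F` gives 148000 nM and compound 2 `N#Cc1ccc(Nc2nccc(N(CCCO)c3c(F)cc(-c4ccc(C#N)cc4)cc3F)n2)cc1` gives 68000 nM. The measured steps read a 2.2-fold lower number from compound 1 to compound 2 (0.34 log units; beyond the scatter), a 15-fold lower number from compound 1 to compound 3 (1.18 log units; beyond the scatter) and a 6.9-fold lower number from compound 2 to compound 3 (0.84 log units; beyond the scatter), so within this small set the hydroxyalkyl chains on the aromatic nitrogen went with lower numbers, the 1-hydroxyethyl case most strongly.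

Compound 4 `N#CCN(c1ccnc(Nc2ccc(C#N)cc2)n1)c1c(F)cc(-c2ccc(C#N)cc2)cc1F` carries cyano in place of 1-hydroxyethyl on a saturated chain carbon bound to a nitrogen on an aromatic ring. Among the measured compounds shown here, no measured step involves a cyano group, so the only bearing steps are those that built up the hydroxyalkyl chain, above all a 15-fold lower number from compound 1 to compound 3 (1.18 log units; beyond the scatter), which is large, and a 6.9-fold lower number from compound 2 to compound 3 (0.84 log units; beyond the scatter), which is modest. Taking the hydroxyl away in compound 4 is expected to undo part of that large drop without any precedent for how far, so the estimated step for compound 4 is a modest to large rise, a 4.1-fold higher number from compound 3 to compound 4 (0.61 log units; beyond the scatter). Compound 4 is estimated at 40000 nM, with a range from 12000 nM to 150000 nM.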

Compound 4, half-maximal cytotoxic concentration: 206000 nM
For compound 4 the middle estimate is 5.2-fold (0.71 log units) below the measured one; measured number above the stated range.
By their numbers in this assay, from the lowest: compound 3; then compound 2; then compounds 1 and 4 (each within the scatter of the next).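

In this assay the step of a 21-fold higher number from compound 3 to compound 4 (1.32 log units; beyond the scatter) removes the whole drop seen with 1-hydroxyethyl on a saturated chain carbon bound to a nitrogen on an aromatic ring. The step of a 3.0-fold higher number from compound 2 to compound 4 (0.48 log units; beyond the scatter) also sets cyano apart from 2-hydroxyethyl at this place, while the step of a 1.4-fold higher number from compound 1 to compound 4 (0.14 log units; within the scatter) leaves cyano and hydrogen at this place indistinguishable. Among these four compounds, the lower numbers therefore belong only to the hydroxyl-bearing compound 2 and compound 3, with no compound going against this.

No evidence is given that bears on this difference between cyano and the hydroxyalkyl chains. Still open, as far as these compounds go, is whether an amine, a carboxylic acid or a longer chain ending in a nitrile at this place would read like compound 1 or like compound 3.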